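Pyridinyl for furanyl on the hydroxyphenyl pyridine series

The source may report more compounds than this note shows. Statements on the series, on what has been measured and on what is new or still open speak of the compounds shown alone.

Of the compounds shown here, three have been measured in a functional assay on HL-60 cells (Homo sapiens) for cytotoxicity, read by ELISA, with a stated time of 2 days; a lower number here means a stronger inhibitor, a higher number a weaker inhibitor. Compound 1 `Oc1cccc(-c2cc(-c3ccccc3)cc(-c3ccco3)n2)c1` gives 9910 nM. Compound 2 `Oc1cccc(-c2cc(-c3ccccc3)cc(-c3ccncc3)n2)c1` gives 23900 nM. Compound 3 `Oc1ccc(-c2cc(-c3ccccc3)nc(-c3ccco3)c2)cc1` gives 13700 nM. Compound 1 and compound 3 are built from the same atoms joined differently; the difference between the two cores is not broken down here. The values of compound 3 against compound 1 and against compound 2 lie within the usual scatter of this assay, so no order among them is claimed.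

One change recurs in the set, twice in all. From compound 1 to compound 2 it is pyridin-4-yl in place of furan-2-yl on an aromatic carbon, and the step it made was a 2.4-fold higher number from compound 1 to compound 2 (0.38 log units; beyond the scatter). Compound 4 `Oc1ccc(-c2cc(-c3ccccc3)nc(-c3ccncc3)c2)cc1` has not yet been measured; it arises from compound 3 by pyridin-4-yl in place of furan-2-yl on an aromatic carbon. The place is described the same, save that in compound 3 it is meta to a 4-hydroxyphenyl group where in compound 1 it is meta to a 3-hydroxyphenyl group; so this is the same kind of change, not the same change.

For compound 4 in this assay the step from compound 3 is expected to resemble the earlier one, a 2.2-fold higher number from compound 3 to compound 4 (0.34 log units; beyond the scatter), because the first occurrence gave a 2.4-fold higher number from compound 1 to compound 2 (0.38 log units; beyond the scatter). With only one prior occurrence the expectation is loose. Compound 4 is thus estimated at 30000 nM, between 14000 nM and 65000 nM.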

Compound 4, half-maximal inhibitory concentration: 1400 nM
Compound 4: the middle estimate sits 21-fold (1.33 log units) above what was measured; the whole stated range lies above it.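

In this assay, pyridin-4-yl in place of furan-2-yl gives a 9.8-fold lower number from compound 3 to compound 4 (0.99 log units; beyond the scatter), so on this core the change goes in the opposite direction to the step seen on the core of compound 1. The change therefore cannot be carried from one core to the other in this series as a fixed increment, in either size or direction: the same change on two cores in this assay, a 2.4-fold higher number (0.38 log units; beyond the scatter) from compound 1 to compound 2 and a 9.8-fold lower number (0.99 log units; beyond the scatter) from compound 3 to compound 4, 24-fold (1.37 log units) apart, beyond the scatter of two such steps This shows that the outcome of the swap depends on the core it is made on, but it rests on a single pair per core and does not show which structural difference between the two cores is responsible, nor how the change would behave on any further core.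

The compounds shown leave open whether the reversal is specific to pyridin-4-yl or also appears with other groups at the same place, such as thiophen-2-yl, pyridin-3-yl, or a phenyl ring bearing an amine or a carboxylic acid. They also leave open whether the reversal persists when the hydroxyl of the hydroxyphenyl group is replaced by a methoxy group, which would help separate the contribution of that group from that of the rest of the core.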